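The source may hold more compounds than are shown below. What is called first, only, known or untested is meant among the compounds shown, and "the series" means these compounds.

Within the data shown here, compound 2 `Cc1nn(-c2nc(-c3ccc(Cl)c(Cl)c3)c(SC(C)C)s2)c(C(=O)O)c1-c1ccccc1` gives the lower of the two numbers so far: in a functional assay on BJAB cells (Homo sapiens) for antiproliferative activity, with a stated time of 4 days (a higher number here means that more compound is needed for the effect, a lower number that less compound is needed), compound 2 gives 3000 nM, while compound 1 `Cc1nn(-c2nc(-c3ccc(Cl)c(Cl)c3)c(SC(C)C)s2)c(C(=O)O)c1-c1cccc(Cl)c1` gives 13600 nM, a step of a 4.5-fold lower number from compound 1 to compound 2 (0.66 log units; beyond the scatter). Compound 3 `CCOc1ncccc1-c1c(C)nn(-c2nc(-c3ccc(Cl)c(Cl)c3)c(SC(C)C)s2)c1C(=O)O` differs from compound 2 by 2-ethoxypyridin-3-yl in place of phenyl on an aromatic carbon. Among the measured compounds shown here, the single measured step, from compound 1 to compound 2, concerns a substituent on that same ring rather than an exchange of the ring, so it bears on this change only loosely, and no step beyond the scatter is expected. Compound 3 is therefore estimated at 3000 nM, within a range of 600 nM to 15000 nM, which means an expected step of no change at the digits printed from compound 2 to compound 3 (within the scatter).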

Compound 3, half-maximal effective concentration: 11000 nM
Compound 3: the middle estimate sits 3.7-fold (0.56 log units) below what was measured; low and high end bracket the measured number.
By their numbers in this assay, from the lowest: compound 2; then compounds 3 and 1 (each within the scatter of the next).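

In this assay, 2-ethoxypyridin-3-yl in place of phenyl gives a 3.7-fold higher number from compound 2 to compound 3 (0.56 log units; beyond the scatter) and so shows that this position also responds to an exchange of the ring itself, not only to a chloro on it. The same group in place of 3-chlorophenyl gives a 1.2-fold lower number from compound 1 to compound 3 (0.09 log units; within the scatter) and leaves these two rings indistinguishable here. No measurement at hand accounts for the higher number of compound 3. The ring nitrogen and the ethoxy group enter together, and the compounds shown do not separate them. On these data alone, whether a plain pyridin-3-yl or a 2-ethoxyphenyl would match compound 2 stays open.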